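Swapping 2,4-difluorophenyl for 2-phenylethenyl in a cytotoxic series

This account rests on a few compounds, and the source may have more. Where it says the series, first, only, none or still open, it means among the compounds named here.

Measured so far in a functional assay on MCF7 cells (Homo sapiens) for cytotoxicity, read by MTT assay, with a stated time of 72 h; on this read-out lower numbers stand for stronger inhibition and higher numbers for weaker inhibition:
- compound 1 `O=C1C(=Cc2ccc(Cl)cc2)C(=O)N(c2ccc(Cl)cc2)N1c1ccc(Cl)cc1` gives 28500 nM
- compound 2 `COc1cccc(C=C2C(=O)N(c3ccc(Cl)cc3)N(c3ccc(Cl)cc3)C2=O)c1OC` gives 11900 nM
- compound 3 `O=C1C(=Cc2ccc(F)cc2F)C(=O)N(c2ccc(Cl)cc2)N1c1ccc(Cl)cc1` gives 22000 nM
- compound 4 `O=C1C(=C/C=C/c2ccccc2)C(=O)N(c2ccc(Cl)cc2)N1c1ccc(Cl)cc1` is still unmeasured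

Compound 3 gives 22000 nM and sits close to both other measured compounds, with steps of a 1.3-fold lower number from compound 1 to compound 3 (0.11 log units; within the scatter) and a 1.8-fold higher number from compound 2 to compound 3 (0.27 log units; within the scatter) on record. Going on to compound 4 brings one structural change 2-phenylethenyl in place of 2,4-difluorophenyl on a double-bonded chain carbon bound to a double-bonded ring carbon that puts 2-phenylethenyl in place of 2,4-difluorophenyl on a double-bonded chain carbon bound to a double-bonded ring carbon.

Going by the values given here, all three measured steps exchange one group at that same place, so they bear on this change, although no measured compound carries 2-phenylethenyl. The largest of them is the modest 2.4-fold lower number from compound 1 to compound 2 (0.38 log units; beyond the scatter) and the other two lie within the scatter. A similarly small step, or none beyond the scatter, is therefore expected in this assay and these data give no firm direction, so a value near the middle of the measured ones is the most reasonable guess. The expected step is a 1.2-fold lower number from compound 3 to compound 4 (0.09 log units; within the scatter) in size. For compound 4 the estimate is 18000 nM with an expected range from 7000 nM to 45000 nM.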

Compound 4, half-maximal inhibitory concentration: 9400 nM
Compound 4: middle estimate off by 1.9-fold (0.28 log units), on the high side, within the range that was stated.
By their numbers in this assay, from the lowest: compounds 4, 2, 3 and 1 (each within the scatter of the next, the first and the last beyond it).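

In this assay, both a 2.3-fold lower number from compound 3 to compound 4 (0.37 log units; beyond the scatter) and a 3.0-fold lower number from compound 1 to compound 4 (0.48 log units; beyond the scatter) are modest but beyond the scatter, so 2-phenylethenyl on a double-bonded chain carbon bound to a double-bonded ring carbon gives a clearer change than the swaps between the two halogenated phenyl groups did, and the group's double bond outside the aromatic ring brings no loss of activity on this read-out. The picture is less simple against 2,3-dimethoxyphenyl, since a 1.3-fold lower number from compound 2 to compound 4 (0.10 log units; within the scatter) lies within the scatter, which means these two differently built groups cannot be ranked against each other and the halogenated groups are the only ones that 2-phenylethenyl separates from. Nothing measured here accounts for these differences, so the data offer no explanation for them.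

From the compounds shown here alone, it remains open whether the double bond of 2-phenylethenyl matters in itself, a question that the saturated 2-phenylethyl group would address. Going by these compounds, it is also open whether a longer chain, or an amine or a carboxylic acid at this place, would move the number further than the modest steps seen so far.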